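Acylating the Ring Nitrogen of Compound 1

The compounds below may be only part of what the source reports. "The series", "measured", "known", "first", "only" and "open" are said of these compounds alone.

Compound 1 `COc1ccc(C2CC(c3ccc(OC)c(OC)c3)=NN2)c(OC)c1` holds the higher of the two measured numbers: in a functional assay on the whole organism (strain albino) for inhibition, with Rattus norvegicus as the target, read by paw edema, with stated times of 30 min and 3 h, at a dose of 100 mg/kg by the oral route (on this read-out higher numbers stand for more inhibition at the one dose given (going by the name of the read-out) and lower numbers for less inhibition), compound 1 gives 42%, while compound 2 `COc1ccc(C2=NN(C(=O)CBr)C(c3c(Cl)cccc3Cl)C2)cc1` gives 7%, a gap beyond the usual scatter. Compound 3 `COc1ccc(C2CC(c3ccc(OC)c(OC)c3)=NN2C(=O)C(C)O[N+](=O)[O-])c(OC)c1` differs from compound 1 by a group of 8 heavy atoms (3 carbon, 1 nitrogen, 4 oxygen; no ring) in place of a hydrogen atom, on an amine nitrogen in a ring. Within the data shown here, no measured pair shares this change, so the step is expected to be small in either direction, likely within the scatter. Compound 3 is therefore expected to give about 45%, between 25% and 65%. That estimate means an expected step of a number 3 percentage points higher from compound 1 to compound 3 (within the scatter).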

Compound 3, a percentage reported as inhibition, in the whole organism at one dose (the size of the read-out at that dose, not a potency): 56%
Beside the measured number, compound 3's estimate is 11 percentage points below it; low and high end bracket the measured number.
By their numbers in this assay, from the lowest: compound 2; then compound 1; then compound 3.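

The amine nitrogen in the ring of compound 1 is thus a position that accepts substitution without loss of the read-out: in this assay, putting the acyl nitrate group in place of the hydrogen atom gives a number 14 percentage points higher from compound 1 to compound 3 (beyond the scatter). Nothing at hand speaks to the reason for this step. On these data alone, what stays open is whether the gain comes from the carbonyl on this nitrogen alone or needs the nitrate ester, which a plain acetyl group at the same place would separate. As far as these compounds go, a longer chain between carbonyl and nitrate ester also remains untested here.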